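The compounds below may be only part of what the source reports. "The series", "measured", "known", "first", "only" and "open" are said of these compounds alone.

In a functional assay on HL-60 cells (Homo sapiens) for antiproliferative activity, read by XTT assay, with a stated time of 72 h (a lower number here means a stronger inhibitor, a higher number a weaker inhibitor), compound 1 `C#Cc1cn([C@@H]2O[C@H](CO)[C@@H](O)[C@H]2O)c2ncnc(SC)c12` gives 50 nM, and compound 2 `CNc1ncnc2c1c(-c1ccco1)cn2[C@@H]1O[C@H](CO)[C@@H](O)[C@H]1O` gives 620 nM. Compound 3 `Nc1nc2c(c(-c3ccoc3)cn2[C@@H]2O[C@H](CO)[C@@H](O)[C@H]2O)c(=O)[nH]1` stands at > 15000 nM, which is a limit of the assay and not a number. As far as these compounds go, it is the only one of the three measured compounds recorded at that limit, so its true position on the scale remains unknown.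

Compound 4 `Nc1nc2c(c(-c3ccsc3)cn2[C@@H]2O[C@H](CO)[C@@H](O)[C@H]2O)c(=O)[nH]1` has thiophen-3-yl in place of furan-3-yl on an aromatic carbon. The rest of the structure is unchanged from compound 3. Among the measured compounds shown here, no measured pair shows this exchange, so any expectation for it has only a limit to start from. The expected change a number no higher from compound 3 to compound 4 (the limit leaves the size open) is none beyond the scatter, in either direction, and compound 4 is expected to remain a very weak inhibitor in this assay. The estimated value for compound 4 is 15000 nM, with an expected range from 6000 nM to 40000 nM. The assay may well report only a limit for it again.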

Compound 4, half-maximal inhibitory concentration: > 20000 nM
Compound 4 gave a limit, no number; the forecaster's own chance of this, stated with the estimate: 65%; middle value at least 1.3-fold (0.12 log units) from the limit.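

In this assay, among the compounds shown here, compound 3 and compound 4 are both recorded only as limits of the assay, and no step between them can be read. The compounds shown leave open whether thiophen-3-yl in place of furan-3-yl changes the read-out at all.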